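The source may hold more compounds than are shown below. What is called first, only, known or untested is meant among the compounds shown, and "the series" means these compounds.

Measured in a functional assay on MGC-803 cells (Homo sapiens) for inhibition, read by MTT assay, with a stated time of 48 h; a higher number here means a weaker inhibitor, a lower number a stronger inhibitor:
compound 1 `Cc1ccc(NC(=S)NC(=O)c2ccc(OCc3ccc(Cl)c(Cl)c3)cc2)cc1-c1nc2ccccc2[nH]1` gives 6390 nM
compound 2 `O=C(NC(=S)Nc1ccc(Cl)c(-c2nc3ccccc3[nH]2)c1)c1ccc(OCc2ccc(Cl)c(Cl)c2)cc1` gives 5170 nM
compound 3 `Cc1ccc(NC(=O)NC(=O)c2ccc(OCc3ccccc3F)cc2)cc1-c1nc2ccccc2[nH]1` gives 2520 nM

Compound 1 and compound 2 differ in one place:
chloro in place of methyl on an aromatic carbon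
This step gave a 1.2-fold lower number from compound 1 to compound 2 (0.09 log units; within the scatter). Compound 3 stands on a different core; the difference between the two cores is not broken down here. In this assay compound 3 gives the lowest number of the three, and its steps to compound 2 and to compound 1 are both beyond the scatter.

Compound 4 `O=C(NC(=O)c1ccc(OCc2ccccc2F)cc1)Nc1ccc(Cl)c(-c2nc3ccccc3[nH]2)c1` has not been measured in this assay. It carries the same change, at the same place, as compound 2 carries against compound 1:
chloro in place of methyl on an aromatic carbon
Because the earlier step of a 1.2-fold lower number from compound 1 to compound 2 (0.09 log units; within the scatter) lies within the scatter, the step of a 1.1-fold lower number from compound 3 to compound 4 (0.06 log units; within the scatter) is expected to be small as well. For compound 4 the estimate is 2200 nM, expected to lie between 1000 nM and 5000 nM.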

Compound 4, half-maximal inhibitory concentration: 120 nM
Beside the measured number, compound 4's estimate is 18-fold (1.26 log units) above it, and the stated range ends above it.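

In this assay, chloro in place of methyl on an aromatic carbon, ortho to a 1H-benzimidazol-2-yl group, gives a 21-fold lower number from compound 3 to compound 4 (1.32 log units; beyond the scatter). The size of the step did not carry from one core to the other: the same change on two cores in this assay, a 1.2-fold lower number (0.09 log units; within the scatter) from compound 1 to compound 2 and a 21-fold lower number (1.32 log units; beyond the scatter) from compound 3 to compound 4, 17-fold (1.23 log units) apart, beyond the scatter of two such steps. This shows that the step seen on one core is a poor guide to the step on the other in this series, but with a single pair on each core it does not show which difference between the cores goes with the larger step.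

The compounds shown leave open whether bromo, methoxy or trifluoromethyl at the same place would give a number close to that of compound 4. From the compounds shown here alone, whether the larger step recurs on any further core also remains open.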